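Hydrazone aryl swap on the shared core: compound 4

The compounds below may be only part of what the source reports. "The series", "measured", "known", "first", "only" and "open" are said of these compounds alone.

Three compounds of the series share one core and differ only in the aryl group on a carbon with a double bond to nitrogen. Compound 1 `Cc1cccc(/C=N/Nc2ncc3c(n2)n(C2CCCC2)c(=O)c(=O)n3C)c1` carries 3-methylphenyl there, compound 2 `Cn1c(=O)c(=O)n(C2CCCC2)c2nc(N/N=C/c3ccc(S(C)(=O)=O)cc3)ncc21` carries 4-(methylsulfonyl)phenyl, and compound 3 `Cn1c(=O)c(=O)n(C2CCCC2)c2nc(N/N=C/c3ccc(F)cc3F)ncc21` carries 2,4-difluorophenyl. In a functional assay on A549 cells (Homo sapiens) for antiproliferative activity, read by MTT assay (a higher number here means a weaker inhibitor, a lower number a stronger inhibitor), compound 1 gives 34500 nM, compound 2 gives 84500 nM, and compound 3 gives 18300 nM. Compound 2 has the highest number of the three: the step of a 4.6-fold lower number from compound 2 to compound 3 (0.66 log units; beyond the scatter) and the step of a 2.4-fold higher number from compound 1 to compound 2 (0.39 log units; beyond the scatter) both lie beyond the scatter, while a 1.9-fold lower number from compound 1 to compound 3 (0.28 log units; within the scatter) stays within it.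

Compound 4 `Cn1c(=O)c(=O)n(C2CCCC2)c2nc(N/N=C/c3ccccc3Cl)ncc21` is the next member. Relative to compound 2 the change is 2-chlorophenyl in place of 4-(methylsulfonyl)phenyl on a carbon with a double bond to nitrogen. Going by the values given here, the steps that bear on it are the two that involve 4-(methylsulfonyl)phenyl: a 4.6-fold lower number from compound 2 to compound 3 (0.66 log units; beyond the scatter) and a 2.4-fold higher number from compound 1 to compound 2 (0.39 log units; beyond the scatter). Both show a lower number whenever that group is absent, and 2-chlorophenyl, with no hydrogen-bond acceptors, resembles the 2,4-difluorophenyl of compound 3 more than the group it replaces. For compound 4 a step of a 3.4-fold lower number from compound 2 to compound 4 (0.53 log units; beyond the scatter) is therefore expected in this assay. The estimate for compound 4 is 25000 nM, with a range from 10000 nM to 60000 nM.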

Compound 4, half-maximal inhibitory concentration: 9860 nM
Compound 4: middle estimate off by 2.5-fold (0.40 log units), on the high side; the whole stated range lies above it.
By their numbers in this assay, from the lowest: compounds 4, 3 and 1 (each within the scatter of the next, the first and the last beyond it); then compound 2.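

In this assay the exchange of 4-(methylsulfonyl)phenyl for 2-chlorophenyl gives an 8.6-fold lower number from compound 2 to compound 4 (0.93 log units; beyond the scatter), the largest step yet seen at this position on a carbon with a double bond to nitrogen, so the spread among these aryl groups is wider than the earlier compounds showed. The series also now separates from 3-methylphenyl on the low side: the change gives a 3.5-fold lower number from compound 1 to compound 4 (0.54 log units; beyond the scatter), whereas compound 3 remained within the scatter of compound 1. Against 2,4-difluorophenyl the change gives a 1.9-fold lower number from compound 3 to compound 4 (0.27 log units; within the scatter), so 2-chlorophenyl and 2,4-difluorophenyl cannot be told apart in this assay, and compound 4 cannot be ranked above compound 3.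

Nothing at hand gives a cause for any of these steps. Still open, as far as these compounds go, is whether the chlorine position matters, which 3-chlorophenyl or 4-chlorophenyl would test, and whether the 4-(methylsulfonyl)phenyl result extends to other aryl groups, such as those carrying a carboxylic acid, an amine or a methoxy group.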